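The source may report more compounds than this note shows. Statements on the series, on what has been measured and on what is new or still open speak of the compounds shown alone.

Compound 1 `CN(C)CC[C@H](CSc1ccccc1)Nc1ccc(S(=O)(=O)NC(=O)c2ccc(N3CCN(Cc4ccccc4-c4ccc(Cl)cc4)CC3)cc2)cc1C(F)(F)F` is the better exposed of the two compounds measured in an ADME assay on the whole organism (plasma, strain Sprague-Dawley) for pharmacokinetics, with Rattus norvegicus as the target, at a dose of 5 mg/kg by the oral route; on this read-out lower numbers stand for lower exposure and higher numbers for higher exposure at the dose given: in this assay compound 1 gives 3690 ng.h/mL, while compound 2 `CN(C)CC[C@H](CSc1ccccc1)Nc1ccc(S(=O)(=O)NC(=O)c2ccc(N3CCN(CC4=C(c5ccc(Cl)cc5)CCCC4)CC3)cc2)cc1[N+](=O)[O-]`, which differs from it in several places, gives 531 ng.h/mL, a gap beyond the scatter. For the measured compounds named here, no single-point step between measured compounds is available, so the move to compound 3 `CN(C)CC[C@H](CSc1ccccc1)Nc1ccc(S(=O)(=O)NC(=O)c2ccc(N3CCN(Cc4ccccc4-c4ccc(Cl)cc4)CC3)cc2)cc1S(=O)(=O)C(F)(F)F` rests on the structural change alone: (trifluoromethyl)sulfonyl in place of trifluoromethyl on an aromatic carbon. The (trifluoromethyl)sulfonyl group enters where the trifluoromethyl group leaves, on an aromatic carbon of the shared core. With only compound 1 as an anchor, the step in this assay is expected to lower exposure by more than the scatter, though not as far as the gap to compound 2; the estimated change from compound 1 to compound 3 is a 2.6-fold lower number from compound 1 to compound 3 (0.42 log units; beyond the scatter). Compound 3 is therefore expected to give about 1400 ng.h/mL in this assay, with a range from 450 ng.h/mL to 4500 ng.h/mL.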

Compound 3, area under the concentration-time curve: 747 ng.h/mL
For compound 3 the middle estimate is 1.9-fold (0.27 log units) above the measured one; the measured number falls inside the stated range.
By their numbers in this assay, from the lowest: compounds 2 and 3 (each within the scatter of the next); then compound 1.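

For the compounds shown here, replacing trifluoromethyl with (trifluoromethyl)sulfonyl on this aromatic carbon gives the first single-point reading at the position: in this assay the change produces a 4.9-fold lower number from compound 1 to compound 3 (0.69 log units; beyond the scatter). Exposure at the oral dose therefore depends on the group held at this place, and here the larger group, with its added hydrogen-bond acceptors, goes with the lower number. Nothing measured here accounts for the size or direction of this step, so it stands as an observation only.

The compounds shown leave open whether the loss follows the sulfonyl unit itself or the whole entering group, a question that methylsulfonyl on the same carbon of compound 1 would address. They also leave open how a nitrile or an amine at this place would compare with trifluoromethyl.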